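A few compounds are considered here, and "the series" means these few. Any claim that something is new, unique, unknown or untested is made for them only; others in the source may bear on it.

Working notes on the urea series.

Two compounds have numbers. Compound 1, `C[C@H](NC(=O)Nc1cccc(C(F)(F)F)c1)c1ccccc1`, is the stronger-looking reference on paper, with 94% in an ADME assay on the whole organism with Oryza sativa as the target, tested at 0.1 uM; a lower number here means a stronger effect, a higher number a weaker effect of the compound at the concentration tested. Compound 2, `C[C@@H](NC(=O)Nc1cccc(I)c1)c1ccccc1`, gives 81% in this assay, the lowest of the two numbers in hand and a gap to compound 1 that lies beyond the scatter. Going by the values given here, no step between these two is set out, since they differ in more than one place, so the pair says only what its two values show.

The next compound, compound 3, is `C[C@H](NC(=O)Nc1cccc(I)c1)c1ccccc1`. It is made from compound 2 by a single change: the two compounds have the same atoms and bonds and differ only in configuration as drawn: 1 of 1 stereo elements differ; a stereocentre at a saturated chain carbon is drawn R in compound 2 and S in compound 3. Nothing leaves and nothing enters; the atoms and bonds are the same and only the configuration at the saturated chain carbon is redrawn.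

Among the compounds with values here, with no step of this kind measured, the expectation is a modest shift, if any, and more likely upward than downward, since compound 1 sits at 94%. Compound 3 is therefore estimated at 87%, within 72% to 98%. This means an expected step of a number 6 percentage points higher from compound 2 to compound 3 (within the scatter), close to the scatter.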

Compound 3, a percentage reported as activity, at one concentration (the size of the read-out at that concentration, not a potency): 98%
Beside the measured number, compound 3's estimate is 11 percentage points below it; low and high end bracket the measured number.
By their numbers in this assay, from the lowest: compound 2; then compounds 1 and 3 (each within the scatter of the next).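

In this assay, going by these compounds alone, the configuration at the saturated chain carbon proves to be a position that can move the read-out: going from R to S gives a number 17 percentage points higher from compound 2 to compound 3 (beyond the scatter) and stands as the first single-place step. The aromatic substituent gets its first single-place reading as well, with iodo in place of trifluoromethyl on an aromatic carbon giving a number 4 percentage points higher from compound 1 to compound 3 (within the scatter) and so no separation between these two groups in this comparison. The larger step can be assigned to the stereocentre alone, and not to any other part of the structure, because of this: the fact that compounds 2 and 3 differ only in the configuration as drawn

Open, as far as these compounds go, is whether a step of this size between the two configurations recurs with trifluoromethyl in place of iodo, or is tied to the iodo compounds alone. Also open, from the compounds shown here alone, is how the read-out responds when the aromatic carbon carries a quite different group, such as an amine or a carboxylic acid, or when the methyl on the chain carbon gives way to a longer chain.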